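This account rests on a few compounds, and the source may have more. Where it says the series, first, only, none or still open, it means among the compounds named here.

Compound 1 `CCCCOc1ccc(C(=O)/C=C/c2c(/C=C/c3ccc(OC)cc3)cc(OC)cc2OC)cc1`: 12.9 ug/mL
Compound 2 `COc1ccc(/C=C/c2cc(OC)cc(OC)c2/C=C/C(=O)c2cccc(Cl)c2)cc1`: 9.5 ug/mL

In a functional assay on HepG2 cells (Homo sapiens) for antiproliferative activity, read by MTT assay, with a stated time of 48 h (a higher number here means a weaker inhibitor, a lower number a stronger inhibitor), compound 2 gives 9.5 ug/mL, which lies within the scatter of compound 1 at 12.9 ug/mL. Compound 3 `COc1ccc(/C=C/c2cc(OC)cc(OC)c2/C=C/C(=O)c2ccc(C(F)(F)F)cc2)cc1`, not yet measured, differs from compound 2 by 4-(trifluoromethyl)phenyl in place of 3-chlorophenyl on a carbonyl carbon. Among the compounds with values here, the only measured step that bears on this, a 1.4-fold lower number from compound 1 to compound 2 (0.13 log units; within the scatter), changed the group at the same carbonyl carbon and stayed within the scatter. No change beyond the scatter is therefore expected, and the estimated step is a 1.1-fold higher number from compound 2 to compound 3 (0.02 log units; within the scatter). For compound 3 the expected value is 10 ug/mL, with an estimated range from 5 ug/mL to 20 ug/mL.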

Compound 3, half-maximal inhibitory concentration: 18.7 ug/mL
Compound 3: the middle estimate sits 1.9-fold (0.27 log units) below what was measured; the measured number falls inside the stated range.
By their numbers in this assay, from the lowest: compounds 2, 1 and 3 (each within the scatter of the next).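

With 4-(trifluoromethyl)phenyl, a third substituted aryl group on the carbonyl carbon is tested in this assay, and the exchange for 3-chlorophenyl gives a 2.0-fold higher number from compound 2 to compound 3 (0.29 log units; within the scatter). Trifluoromethyl in place of butoxy on an aromatic carbon gives a 1.4-fold higher number from compound 1 to compound 3 (0.16 log units; within the scatter), so neither change leaves the scatter and this position has not yet shown a clear effect. Nothing available explains these readings. As far as these compounds go, it remains open whether a phenyl group carrying an amine, a carboxylic acid or a longer chain at this carbonyl carbon would move the number beyond the scatter.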